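Removing a ring fluorine: a second look at one change

The source may hold more compounds than are shown below. What is called first, only, known or untested is meant among the compounds shown, and "the series" means these compounds.

Measured so far:
compound 1, `CCC1(CCCCN2CCN(c3ccc(F)cc3)CC2)C(=O)Nc2ccc(F)cc21`, 1.5 nM
compound 2, `CCC1(CCCCN2CCN(c3ccc(F)cc3)CC2)C(=O)Nc2ccccc21`, 0.43 nM
compound 3, `O=C1Nc2ccc(F)cc2C1CCCCN1CCN(c2cccc(Cl)c2)CC1`, 1.96 nM

All three were tested in an assay on CHO cells for displacement of a labelled ligand from 5-hydroxytryptamine receptor 7 (Homo sapiens); on this read-out lower numbers stand for stronger inhibition and higher numbers for weaker inhibition. Compound 1 and compound 2 differ by one change, (hydrogen in place of fluoro on an aromatic carbon), and this change gave a 3.5-fold lower number from compound 1 to compound 2 (0.54 log units; beyond the scatter). Compound 3 has a different core from compound 1; how the two cores differ is not broken down here. Its value in this assay sits close to that of compound 1 and further from that of compound 2.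

Compound 4, `O=C1Nc2ccccc2C1CCCCN1CCN(c2cccc(Cl)c2)CC1`, has not yet been measured. It differs from compound 3 by hydrogen in place of fluoro on an aromatic carbon, the same change that separates compound 1 from compound 2, in the same place on the ring. Starting from compound 3, the step to compound 4 is expected to be a 3.3-fold lower number from compound 3 to compound 4 (0.51 log units; beyond the scatter), resting on the step seen earlier from compound 1 to compound 2. Compound 4 is therefore estimated at 0.6 nM in this assay, with a likely range from 0.25 nM to 1.5 nM.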

Compound 4, inhibition constant: 0.49 nM
Compound 4: the middle estimate sits 1.2-fold (0.09 log units) above what was measured; low and high end bracket the measured number.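

In this assay, hydrogen in place of fluoro on the aromatic carbon gave a 4.0-fold lower number from compound 3 to compound 4 (0.60 log units; beyond the scatter), so the number fell on this core as well. Set beside the earlier case, the change behaved alike on the two cores: the same change on two cores in this assay, a 3.5-fold lower number (0.54 log units; beyond the scatter) from compound 1 to compound 2 and a 4.0-fold lower number (0.60 log units; beyond the scatter) from compound 3 to compound 4, 1.1-fold (0.06 log units) apart, within the scatter of two such steps. For these two pairs, then, the size of the step carried over from the core of compound 1 to the core of compound 3, but two pairs do not make a rule for the whole series, and they show neither why the step occurs nor whether it would appear in any other read-out.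

The compounds shown leave open how a methoxy group or a nitrile would compare with fluoro and hydrogen on that same aromatic carbon. They also leave open whether the step would keep its size with a shorter chain linking the two ends of the molecule.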